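The source may report more compounds than this note shows. Statements on the series, on what has been measured and on what is new or still open speak of the compounds shown alone.

Series notes. The shared core carries a propylamino group in compound 1 `CCCNc1nc(N)nc2c1ncn2/C=C1/CC1(CO)CO`, an isobutylamino group in compound 2 `CC(C)CNc1nc(N)nc2c1ncn2/C=C1/CC1(CO)CO` and a cyclopentylsulfanyl group in compound 3 `Nc1nc(SC2CCCC2)c2ncn(/C=C3/CC3(CO)CO)c2n1`. In an ADME assay on BCBL1 cells (Homo sapiens) for cytotoxicity, with a stated time of 7 days (on this read-out higher numbers stand for lower toxicity in this test and lower numbers for higher toxicity in this test), compound 1 gives only a limit, > 20000 nM. In this assay compound 2 gives only a limit, > 20000 nM. In this assay compound 3 gives only a limit, > 20000 nM. The steps between them are therefore a step that the two limits leave unreadable from compound 1 to compound 2, a step that the two limits leave unreadable from compound 1 to compound 3 and a step that the two limits leave unreadable from compound 2 to compound 3, and compound 3 stands where its two neighbours stand, namely at the limit of > 20000 nM in this assay, at which 3 of the 3 values shown sit.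

The next compound is compound 4 `CC(C)Sc1nc(N)nc2c1ncn2/C=C1/CC1(CO)CO`. The change from compound 3: isopropyl in place of cyclopentyl on a sulfur. Within the data shown here, the steps that bear on it are a step that the two limits leave unreadable from compound 1 to compound 3 and a step that the two limits leave unreadable from compound 2 to compound 3, both unreadable in size; no measured step alters the alkyl group on the sulfur itself, so the expectation rests on all three values sitting together at the limit of > 20000 nM in this assay, at which 3 of the 3 values shown sit. In this assay the expected step is a step that the limit leaves unreadable from compound 3 to compound 4, nothing beyond the scatter. Compound 4 is estimated to give 25000 nM in this assay, within 10000 nM to 60000 nM, most probably reported once more only as a limit.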

Compound 4, half-maximal cytotoxic concentration: > 20000 nM
Compound 4 ended at the assay's limit; the forecaster's own chance of this, stated with the estimate: 85%; the middle value does not contradict the limit.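

No step to compound 4 from compound 1, compound 2 or compound 3 can be read in this assay, since compound 4 also gives only a limit: the limit of > 20000 nM in this assay, at which 4 of the 4 values shown sit.

The compounds shown leave open whether exchanging these groups on the shared core changes this read-out at all, and by how much.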